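Swapping a Halogenated Phenyl on a Triazole-Bearing Sesquiterpenoid

The compounds below may be only part of what the source reports. "The series", "measured", "known", "first", "only" and "open" are said of these compounds alone.

Four compounds are considered here. Compound 1 `CC(C)=CCC/C(C)=C/CC/C(C)=C/CC[C@@H]1[C@@]2(C)CC/C(=N\OCc3cn(-c4ccc(Cl)cc4)nn3)C(C)(C)[C@@H]2CC[C@@]1(C)O` and compound 2 `CC(C)=CCC/C(C)=C/CC/C(C)=C/CC[C@@H]1[C@@]2(C)CC/C(=N\OCc3cn(-c4cccc(Br)c4)nn3)C(C)(C)[C@@H]2CC[C@@]1(C)O` share a core that carries an oxime ether; compound 3 `CC(C)=CCC/C(C)=C/CC/C(C)=C/CC[C@@H]1[C@@]2(C)C/C(=C\c3ccc(OCc4cn(-c5ccc(Cl)cc5)nn4)cc3)C(=O)C(C)(C)[C@@H]2CC[C@@]1(C)O` and compound 4 `CC(C)=CCC/C(C)=C/CC/C(C)=C/CC[C@@H]1[C@@]2(C)C/C(=C\c3ccc(OCc4cn(-c5cccc(Br)c5)nn4)cc3)C(=O)C(C)(C)[C@@H]2CC[C@@]1(C)O` share a different core in which a ketone and an exocyclic double bond lead to a phenyl ether. How the two cores differ is not broken down here.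

In a functional assay on HeLa cells (Homo sapiens) for cytotoxicity, read by MTT assay, with a stated time of 48 h (on this read-out higher numbers stand for weaker inhibition and lower numbers for stronger inhibition), compound 1 gives 14800 nM. Compound 2 gives 15700 nM in this assay, and the change from compound 1 to compound 2 is 3-bromophenyl in place of 4-chlorophenyl on an aromatic nitrogen; the step it made is a 1.1-fold higher number from compound 1 to compound 2 (0.03 log units; within the scatter). Compound 3 gives 50700 nM in this assay, a number that stands apart from those of compound 1 and compound 2 by more than the scatter.

Compound 4 is not yet measured in this assay. It differs from compound 3 by 3-bromophenyl in place of 4-chlorophenyl on an aromatic nitrogen, which is the same kind of change as that from compound 1 to compound 2, made at a place described in the same words. Within the data shown here, the one measured example of this change moved the number hardly at all, so compound 4 is expected to sit close to compound 3, and the step expected from compound 3 to compound 4 is a 1.1-fold higher number from compound 3 to compound 4 (0.03 log units; within the scatter), resting on a 1.1-fold higher number from compound 1 to compound 2 (0.03 log units; within the scatter). The estimate for compound 4 in this assay is 54000 nM, with a range of 25000 nM to 110000 nM.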

Compound 4, half-maximal inhibitory concentration: 37200 nM
Estimate against measurement, compound 4: 1.5-fold (0.16 log units) above; the measured number falls inside the stated range.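

In this assay, putting 3-bromophenyl in place of 4-chlorophenyl on an aromatic nitrogen of the core of compound 3 gives a 1.4-fold lower number from compound 3 to compound 4 (0.13 log units; within the scatter). Set beside the same change on the core of compound 1, the two steps agree, and neither core shows a shift that can be told from assay noise: the same change on two cores in this assay, a 1.1-fold higher number (0.03 log units; within the scatter) from compound 1 to compound 2 and a 1.4-fold lower number (0.13 log units; within the scatter) from compound 3 to compound 4, 1.4-fold (0.16 log units) apart, within the scatter of two such steps. Among these compounds, this shows that, across these two pairs, the change carried from one core to the other with no detectable difference in its outcome, but it rests on only two steps in a single assay, cannot establish a rule for other cores, and cannot separate the exchange of chlorine for bromine from the move to a different place on the phenyl ring, since the two travel together in both pairs.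

The compounds shown leave open whether the same flat outcome would hold for a group of another kind on that nitrogen, such as an unsubstituted phenyl, a benzyl, or a phenyl bearing an amine or a carboxylic acid. They also leave open whether either core would respond to such groups in the same way as the other.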